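The source may report more compounds than this note shows. Statements on the series, on what has been measured and on what is new or still open speak of the compounds shown alone.

Measured compounds:
compound 1 `CCOC(=O)Cn1cc(CNC(=O)c2cnc(Nc3ccc(C#N)cc3)cc2Oc2c(C)cc(C)cc2C)nn1` – 9530 nM
compound 2 `CCOC(=O)CCn1cc(CNC(=O)c2cnc(Nc3ccc(C#N)cc3)cc2Oc2c(C)cc(C)cc2C)nn1` – 21500 nM
compound 3 `Cc1cc(C)c(Oc2cc(Nc3ccc(C#N)cc3)ncc2C(=O)NCc2cn(CC(=O)N3CCOCC3)nn2)c(C)c1` – 181000 nM

In an ADME assay on MT4 cells (Homo sapiens) for cytotoxicity, read by MTT assay, with a stated time of 5 days (a lower number here means that less compound is tolerated, a higher number that more compound is tolerated), compound 3 gives the highest number of the three, the nearest being compound 2 and the furthest compound 1, so of these it is the one whose cells tolerate the most. Compound 4 `Cc1cc(C)c(Oc2cc(Nc3ccc(C#N)cc3)ncc2C(=O)NCc2cn(Cc3ccccc3C)nn2)c(C)c1` differs from compound 3 in a single place: 2-methylphenyl in place of (morpholin-4-yl)carbonyl on a saturated chain carbon bound to an aromatic nitrogen. The measured steps all concern groups on this same side chain: a 2.3-fold higher number from compound 1 to compound 2 (0.35 log units; beyond the scatter) was modest, an 8.4-fold higher number from compound 2 to compound 3 (0.93 log units; beyond the scatter) was modest, and a 19-fold higher number from compound 1 to compound 3 (1.28 log units; beyond the scatter) was large. That last step shows how much of the high number of compound 3 is tied to the morpholin-4-yl carbonyl group, and compound 4 loses exactly that group, taking on a 2-methylphenyl ring with no hydrogen-bond acceptors instead. Among the compounds with values here, no measured step covers an aromatic ring in this position, so the direction rests on reversing the entry of that group. Compound 4 is therefore expected to give a lower number in this assay than compound 3, a step of a 15-fold lower number from compound 3 to compound 4 (1.18 log units; beyond the scatter), landing near or somewhat under the numbers of compound 1 and compound 2. The estimate for compound 4 is 12000 nM, within 3000 nM to 50000 nM.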

Compound 4, half-maximal cytotoxic concentration: >= 164000 nM
Compound 4 was reported as a limit; the forecaster's own chance of this, stated with the estimate: 10%; at least 13-fold (1.13 log units) between middle value and limit.
By their numbers in this assay, from the lowest: compound 1; then compound 2; then compound 3.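

Compound 4 is reported in this assay as a limit and not as a number: the limit of >= 164000 nM in this assay, at which 1 of the 4 values shown sits.

The step from compound 3 to compound 4 therefore cannot be read, but the steps from the two compounds carrying ethoxycarbonyl can: an at least 7.6-fold higher number from compound 2 to compound 4 (0.88 log units; beyond the scatter) and an at least 17-fold higher number from compound 1 to compound 4 (1.23 log units; beyond the scatter). Until now, the only high number in this series belonged to the compound with (morpholin-4-yl)carbonyl, which could suggest that this group was needed for it; compound 4 shows that it is not, since 2-methylphenyl, with 0 hydrogen-bond acceptors, on the same saturated chain carbon bound to an aromatic nitrogen also stands well clear of compound 1 and compound 2, so among these four compounds the low numbers go with the ethoxycarbonyl compounds and no compound goes against this.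

Which of compound 3 and compound 4 is better tolerated stays open, as does how far the number of compound 4 really lies past its limit. Also open, as far as these compounds go, is whether a carboxylic acid, an amine or a plain phenyl ring on this chain carbon would keep the number high, or whether the ethoxycarbonyl compounds are the exception.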